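This account rests on a few compounds, and the source may have more. Where it says the series, first, only, none or still open, it means among the compounds named here.

Measured so far in an ADME assay on the whole organism (Rattus norvegicus, strain Sprague-Dawley) for pharmacokinetics, read by LC-MS, at a dose of 1 mg/kg by the intravenous route; on this read-out lower numbers stand for slow clearance and higher numbers for fast clearance:
- compound 1 `Cc1cccc(Cl)c1CN1CCc2cc(-c3c(C)nc(C)c([C@H](OC(C)(C)C)C(=O)O)c3N3CCC(C)(C)CC3)ccc2C1` at 3.5 mL/min/kg 
- compound 2 `Cc1cccc(F)c1CN1CCc2cc(-c3c(C)nc(C)c([C@H](OC(C)(C)C)C(=O)O)c3N3CCC(C)(C)CC3)ccc2C1` at 5.8 mL/min/kg 

Among the measured compounds shown here, compound 2 at 5.8 mL/min/kg stands within the scatter of compound 1, and these are the only two numbers. Compound 3 `Cc1nc(C)c([C@H](OC(C)(C)C)C(=O)O)c(N2CCC(C)(C)CC2)c1-c1ccc2c(c1)CCN(Cc1cccc(F)c1C)C2` has the same atoms as compound 2, joined differently. The change is 3-fluoro-2-methylphenyl in place of 2-fluoro-6-methylphenyl on a saturated chain carbon bound to an amine nitrogen in a ring and, cut one bond further out, it reads 2-fluoro-6-methylbenzyl to 3-fluoro-2-methylbenzyl.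

For the measured compounds named here, only one measured step bears on this change: a 1.7-fold higher number from compound 1 to compound 2 (0.22 log units; within the scatter) and it lies within the scatter. That step puts fluoro in place of chloro and rearranges nothing, so it is an indirect guide. Going by the values given here, no measured pair tests a rearrangement of this kind. The data therefore support no direction in this assay and no step beyond the scatter is expected. The estimated step is a 1.1-fold higher number from compound 2 to compound 3 (0.05 log units; within the scatter) and it is expected to stay within the scatter. For compound 3 the estimated value is 6.5 mL/min/kg with an expected range from 3 mL/min/kg to 14 mL/min/kg as its limits.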

Compound 3, clearance: 4 mL/min/kg
For compound 3 the middle estimate is 1.6-fold (0.21 log units) above the measured one; measured number inside the range.
By their numbers in this assay, from the lowest: compounds 1, 3 and 2 (each within the scatter of the next).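

In this assay the swap of 3-fluoro-2-methylphenyl for 2-fluoro-6-methylphenyl on a saturated chain carbon bound to an amine nitrogen in a ring gives a 1.5-fold lower number from compound 2 to compound 3 (0.16 log units; within the scatter) and this is the only rearrangement of the same atoms among the compounds shown. The same group set against the 2-chloro-6-methylphenyl of compound 1 gives a 1.1-fold higher number from compound 1 to compound 3 (0.06 log units; within the scatter) and so a change of halogen and a rearrangement of the substituents have now both been read at this place, with no step beyond the scatter in either case. No measurement at hand accounts for these steps.

Still open, going by these compounds, is whether a larger change at this place would leave the scatter: a benzyl carrying a methoxy, a nitrile or a trifluoromethyl group, or a pyridylmethyl in place of the benzyl, could stay within it or move clearance beyond it. Also open, on these data alone, is how far the rest of the shared core governs this read-out, for instance with an amide or a tetrazole in place of the carboxylic acid.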